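This account rests on a few compounds, and the source may have more. Where it says the series, first, only, none or still open, it means among the compounds named here.

Measured so far:
compound 1 `O=C(Nc1cccc(-n2cc(-c3ccncc3)c(-c3ccc(Cl)c(O)c3)n2)c1)Nc1cccc(C(F)(F)F)c1` — > 32500 nM
compound 2 `COc1cc(-c2nn(-c3cccc(NC(=O)Nc4cc(C(F)(F)F)cc(C(F)(F)F)c4)c3)cc2-c2ccncc2)ccc1Cl` — 3380 nM
compound 3 `COc1cc(-c2nn(-c3cccc(NC(=O)c4cccc(C(F)(F)F)c4)c3)cc2-c2ccncc2)ccc1Cl` — > 50000 nM

In a functional assay on SK-MEL-28 cells (Homo sapiens) for inhibition, read by sulforhodamine B assay, with a stated time of 48 h (on this read-out lower numbers stand for higher toxicity in this test and higher numbers for lower toxicity in this test), compound 1 gives > 32500 nM, a limit of the assay rather than a number (the limit of > 32500 nM in this assay, at which 1 of the 3 values shown sits). Compound 3 gives > 50000 nM, also a limit (the limit of > 50000 nM in this assay, at which 1 of the 3 values shown sits). Compound 2 gives 3380 nM. Among the measured compounds shown here, compound 1 thus stands among the compounds for which only a limit is known in this assay, and no step between measured compounds exists to size the change to compound 4 `O=C(Nc1cccc(-n2cc(-c3ccncc3)c(-c3ccc(Cl)c(O)c3)n2)c1)Nc1ccc(Cl)c(Cl)c1`: 3,4-dichlorophenyl in place of 3-(trifluoromethyl)phenyl on an amide-type nitrogen. With nothing measured on this change, the expectation is a small move toward higher toxicity, hardly beyond the scatter, estimated as an at least 2.1-fold lower number from compound 1 to compound 4 (0.33 log units; beyond the scatter). Compound 4 is therefore expected near 15000 nM, within 4000 nM to 50000 nM.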

Compound 4, concentration lethal to 50% of the cells: > 32500 nM
Compound 4 gave a limit, no number; the forecaster's own chance of this, stated with the estimate: 50%; middle value at least 2.1-fold (0.33 log units) from the limit.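

Compound 1 and compound 4 both stand at a limit in this assay, so no step between them can be read: the limit of > 32500 nM in this assay, at which 2 of the 4 values shown sit.

The compounds shown leave open whether 3,4-dichlorophenyl and 3-(trifluoromethyl)phenyl differ at all in this assay.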